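The compounds below may be only part of what the source reports. "The series", "measured", "known", "first", "only" and "open" are said of these compounds alone.

Compound 2 `CCCCCCCc1cccc(N2CCNCC2)n1` is the starting point of this step. Among the measured compounds shown here, in a functional assay on the whole organism with Mus musculus as the target, in the maximal electroshock model, with a stated time of 120 min (a lower number here means that less compound is needed, a higher number that more compound is needed for the effect), compound 2 gives 10 mg/kg, and its only measured neighbour is compound 1 `CCCc1cccc(N2CCNCC2)n1`, which in this assay gives 10 mg/kg. The step from compound 1 to compound 2 was no change at the digits printed from compound 1 to compound 2 (within the scatter), for a change of butyl in place of hydrogen on a saturated chain carbon, three bonds along the chain from an aromatic carbon; in other words, growing the chain on the shared core changed nothing within the scatter.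

Compound 3 `c1ccc(CCc2cccc(N3CCNCC3)n2)cc1` is the next compound, and it differs from compound 2 as follows: phenyl in place of pentyl on a saturated chain carbon, two bonds along the chain from an aromatic carbon. For the measured compounds named here, the one measured step bears on this only loosely, since it concerned a longer or shorter chain rather than an aromatic ring entering where part of the chain was. Nothing measured here speaks for either direction, so the expectation for compound 3 in this assay is a step of no change at the digits printed from compound 2 to compound 3 (within the scatter), that is none beyond the scatter, with compound 3 estimated at 10 mg/kg, between 5 mg/kg and 30 mg/kg.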

Compound 3, minimum effective dose: > 300 mg/kg
Compound 3: only a limit was reported; the forecaster's own chance of this, stated with the estimate: 10%; at least 30-fold (1.47 log units) between middle value and limit.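

In this assay, phenyl in place of pentyl on a saturated chain carbon, two bonds along the chain from an aromatic carbon, gives an at least 30-fold higher number from compound 2 to compound 3 (1.47 log units; beyond the scatter), and phenyl in place of methyl at that same place gives an at least 30-fold higher number from compound 1 to compound 3 (1.47 log units; beyond the scatter). From the compounds shown here alone, both steps rest on a value for compound 3 that is a limit of the assay and not a number, so their full size is unknown: the limit of > 300 mg/kg in this assay, at which 1 of the 3 values shown sits. The earlier compounds shown here showed only that this chain could carry butyl with no change at the digits printed from compound 1 to compound 2 (within the scatter), whereas compound 3 shows that the same position does not accept every carbon-only group, since an aromatic ring here goes with a far higher dose than either open chain.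

The compounds shown do not separate the effect of having a ring at this place from the effect of having an aromatic one, which cyclohexyl, a saturated six-membered ring of carbon, could address. They also leave open whether phenyl set farther along a longer chain, or a phenyl ring carrying a methoxy group or a fluorine, would behave as compound 3 does.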